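Shortening the Carbamate Chain Toward a Fluoromethylphenyl Group

The source may hold more compounds than are shown below. What is called first, only, known or untested is meant among the compounds shown, and "the series" means these compounds.

Compound 1 `COc1ccc(CCOC(=O)N(c2ccccc2)C2CN3CCC2CC3)cc1`: 230 nM
Compound 2 `COc1ccc(CCCOC(=O)N(c2ccccc2)C2CN3CCC2CC3)cc1`: 640 nM

In an assay on CHO cells for displacement of a labelled ligand from muscarinic acetylcholine receptor M5 (Homo sapiens), read by scintillation counting, with a stated time of 2 h (a higher number here means a weaker inhibitor, a lower number a stronger inhibitor), compound 1 gives 230 nM, the lowest of the two numbers; its nearest neighbour is compound 2, where the step of a 2.8-fold higher number from compound 1 to compound 2 (0.44 log units; beyond the scatter) lengthens the chain by one carbon. Compound 3 `Cc1ccc(COC(=O)N(c2ccccc2)C2CN3CCC2CC3)cc1F` goes the other way: 3-fluoro-4-methylphenyl in place of 4-methoxybenzyl on a saturated chain carbon bound to an oxygen next to a carbonyl group. Within the data shown here, only the step from compound 1 to compound 2 bears on this, and it concerns chain length alone, not the ring substitution, so it guides the direction loosely. A modest weakening, a 1.7-fold higher number from compound 1 to compound 3 (0.24 log units; within the scatter), is expected. Compound 3 is therefore estimated at 400 nM in this assay, with a range from 120 nM to 1300 nM.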

Compound 3, inhibition constant: 30 nM
Estimate against measurement, compound 3: 13-fold (1.12 log units) above; measured number outside the range, below it.
By their numbers in this assay, from the lowest: compound 3; then compound 1; then compound 2.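

In this assay, among these compounds, replacing 4-methoxybenzyl with 3-fluoro-4-methylphenyl on the saturated chain carbon gives a 7.7-fold lower number from compound 1 to compound 3 (0.88 log units; beyond the scatter), so a change at this place can lower the number, whereas the only earlier step, a 2.8-fold higher number from compound 1 to compound 2 (0.44 log units; beyond the scatter), raised it. The swap removes the methoxy group and brings in fluorine and methyl together, so the shown compounds do not assign the step to any one of these features. No evidence is available to explain the step.

Going by these compounds, it remains open how an unsubstituted phenyl, a 4-methylphenyl or a 3-fluorophenyl would compare at this place. On these data alone, the effect of a 3-chloro-4-methylphenyl group also remains open.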